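From formyl to hydroxymethyl at the cytotoxicity limit

A few compounds are considered here, and "the series" means these few. Any claim that something is new, unique, unknown or untested is made for them only; others in the source may bear on it.

In an ADME assay on BJ cells (Homo sapiens) for cytotoxicity, with a stated time of 72 h (a higher number here means that more compound is needed for the effect, a lower number that less compound is needed), compound 3 `C=C[C@@](C)(/C=C/c1ccc(O)cc1)CC/C=C(\C)C=O` gives > 36600 nM, which is a limit and not a number. Compound 1 `C=C[C@@](C)(/C=C/c1ccc(O)cc1)CCC=O` gives > 36600 nM, also a limit. Compound 2 `C=C[C@@](C)(/C=C/c1ccc(O)cc1)CC/C=C(C)/C=N/N` gives > 36600 nM, again a limit. All three compounds thus stand at the limit of > 36600 nM in this assay, at which 3 of the 3 values shown sit. Compound 4 `C=C[C@@](C)(/C=C/c1ccc(O)cc1)CC/C=C(\C)CO` differs from compound 3 by hydroxymethyl in place of formyl on a double-bonded chain carbon bound to a double-bonded chain carbon and a saturated chain carbon, with hydroxymethyl in place of formyl. The steps bearing on this change are a step that the two limits leave unreadable from compound 2 to compound 3, which falls at the same place, together with a step that the two limits leave unreadable from compound 1 to compound 3 and a step that the two limits leave unreadable from compound 1 to compound 2, and none of them gives a size. In this assay the expected result is a step that the limit leaves unreadable from compound 3 to compound 4, with no shift beyond the scatter. Compound 4 is estimated at 45000 nM, within a range of 20000 nM to 100000 nM.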

Compound 4, half-maximal effective concentration: > 36600 nM
Compound 4: a limit, no number; the forecaster's own chance of this, stated with the estimate: 85%; the middle value lies beyond the limit too.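

No step can be read between compound 4 and compound 1, compound 2 or compound 3, as all four values are limits: the limit of > 36600 nM in this assay, at which 4 of the 4 values shown sit.

Going by these compounds, whether compound 1, compound 2, compound 3 and compound 4 differ from one another at all stays open.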